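Thiocarbamate series: oxygen for sulfur in the bridge

The source may report more compounds than this note shows. Statements on the series, on what has been measured and on what is new or still open speak of the compounds shown alone.

Measured compounds and values in a physicochemical assay for lipophilicity; a higher number here means a more lipophilic compound, a lower number a more polar compound:
- compound 1 `CC(=O)Nc1ccc(OC(=S)Nc2ccc(Nc3ccc([N+](=O)[O-])cc3)cc2)cc1`, 4.32
- compound 2 `O=[N+]([O-])c1ccc(Oc2ccc(NC(=S)Oc3ccc(O)cc3)cc2)cc1`, 5.01
- compound 3 `CC(=O)Nc1ccc(OC(=S)Nc2ccc(Sc3ccc([N+](=O)[O-])cc3)cc2)cc1`, 5.06

Compound 3 gives the highest number of the three in this assay; compound 2 sits within the scatter of it, while compound 1 is the furthest away and lies beyond the scatter below it. Going by the values given here, the one step that connects two measured compounds is a number 0.74 log units higher from compound 1 to compound 3 (beyond the scatter).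

The next compound, compound 4 `CC(=O)Nc1ccc(OC(=S)Nc2ccc(Oc3ccc([N+](=O)[O-])cc3)cc2)cc1`, differs from compound 3 in one place: 4-nitrophenoxy in place of (4-nitrophenyl)sulfanyl on an aromatic carbon. Among the compounds with values here, no measured pair shows this exact exchange. The step from compound 1 to compound 3 concerns a different pair of bridging groups and only shows that the bridge atom can move the number by a modest amount. Compound 2 carries the same bridge as compound 4 but a different end group, and its value in this assay is close to that of compound 3.

Compound 4 is therefore expected to come out somewhat lower than compound 3, with a number 0.46 log units lower from compound 3 to compound 4 (beyond the scatter) as the expected step. The estimate for compound 4 is 4.6, with a range from 4.1 to 5.1.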

Compound 4, partition coefficient: 4.81
Compound 4: the middle estimate sits 0.21 log units below what was measured; low and high end bracket the measured number.
By their numbers in this assay, from the lowest: compound 1; then compounds 4, 2 and 3 (each within the scatter of the next).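

In this assay, 4-nitrophenoxy in place of (4-nitrophenyl)sulfanyl on this aromatic carbon gives a number 0.25 log units lower from compound 3 to compound 4 (within the scatter) and so does not separate the two groups, while 4-nitrophenoxy in place of (4-nitrophenyl)amino gives a number 0.49 log units higher from compound 1 to compound 4 (beyond the scatter) and places the amino-linked group apart from both of the others. The end group can now be read as well: with 4-nitrophenoxy kept, acetamido in place of hydroxy gives a number 0.20 log units lower from compound 2 to compound 4 (within the scatter) and leaves the two compounds unseparated. No measurement at hand accounts for any of these steps.

Still open, as far as these compounds go, is whether a methylene or a carbonyl as the bridge at this position would fall with the oxygen and sulfur bridges or with the amino bridge. Also open, from the compounds shown here alone, is how far the number moves with a carboxylic acid or an amine in place of acetamido on the end ring.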